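Cytotoxicity of the chloroaryl series and a thiazolyl analogue

The source may report more compounds than this note shows. Statements on the series, on what has been measured and on what is new or still open speak of the compounds shown alone.

Measured compounds:
Compound 1 `COc1nc(-c2cccc(Cl)c2)ccc1[C@@H](c1ccccc1)[C@@](O)(CCN(C)C)c1cccc2ccccc12` — in a toxicity assay on Vero cells (Chlorocebus sabaeus) for cytotoxicity (on this read-out higher numbers stand for lower toxicity in this test and lower numbers for higher toxicity in this test), compound 1 gives > 50 ug/mL, a limit of the assay.
Compound 2 `COc1nc(-c2ccccc2Cl)ccc1[C@@H](c1ccccc1)[C@@](O)(CCN(C)C)c1cccc2ccccc12` — in this assay compound 2 gives > 50 ug/mL, a limit of the assay.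
Compound 3 `COc1nc(-c2ccc(Cl)cc2)ccc1[C@@H](c1ccccc1)[C@@](O)(CCN(C)C)c1cccc2ccccc12` — in this assay compound 3 gives > 50 ug/mL, a limit of the assay.

Compound 1 stands at the limit, as do both other measured compounds (the limit of > 50 ug/mL in this assay, at which 3 of the 3 values shown sit). The steps a step that the two limits leave unreadable from compound 1 to compound 2 and a step that the two limits leave unreadable from compound 1 to compound 3 are therefore unreadable, and so is a step that the two limits leave unreadable from compound 2 to compound 3. Compound 4 `COc1nc(-c2cnsc2)ccc1[C@@H](c1ccccc1)[C@@](O)(CCN(C)C)c1cccc2ccccc12` is unmeasured; the change is 1,2-thiazol-4-yl in place of 3-chlorophenyl on an aromatic carbon. Moving the chlorine around the phenyl ring left no readable step, so there is no measured basis for expecting a readable step in this assay here either. Compound 4 is expected to sit at the limit as well, an estimated 60 ug/mL (range 30 ug/mL to 120 ug/mL), which would mean an expected step that the limit leaves unreadable from compound 1 to compound 4.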

Compound 4, half-maximal cytotoxic concentration: 26.3 ug/mL
Beside the measured number, compound 4's estimate is 2.3-fold (0.36 log units) above it; measured number below the stated range.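

Among the compounds shown here, at this position, next to the ring nitrogen, 1,2-thiazol-4-yl gives the only number in this assay that is not a limit, which makes the change readable as a direction: an at least 1.9-fold lower number from compound 1 to compound 4 (0.27 log units; that floor lies within the scatter), an at least 1.9-fold lower number from compound 2 to compound 4 (0.27 log units; that floor lies within the scatter) and an at least 1.9-fold lower number from compound 3 to compound 4 (0.27 log units; that floor lies within the scatter). Each of these is only a floor, and the steps among compound 1, compound 2 and compound 3 remain unreadable. Their true size stays unknown because the chloroaryl values all rest on the limit: the limit of > 50 ug/mL in this assay, at which 3 of the 4 values shown sit.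

From the compounds shown here alone, whether an unsubstituted phenyl, a pyridin-3-yl or a 1,3-thiazol-5-yl at this position would also give a number short of the limit stays open. So does the question of how much of the step belongs to the ring and how much to the loss of chlorine.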